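Replacing a Cyclopropyl Amide with a 2-Chlorophenyl Amide

The source may hold more compounds than are shown below. What is called first, only, known or untested is meant among the compounds shown, and "the series" means these compounds.

Of the compounds shown here, three sharing one core have been measured in a functional assay on HepG2 cells (Homo sapiens) for inhibition, read by MTT assay, with a stated time of 72 h; a lower number here means a stronger inhibitor, a higher number a weaker inhibitor. Compound 1 `Cc1noc(C)c1-c1cnc(N)c(Oc2ccc(C(=O)NC3CC3)cc2)n1` gives 43200 nM, the highest of the three numbers. Compound 2 `Cc1noc(C)c1-c1cnc(N)c(Oc2ccc(C(=O)NC3CCCCC3)cc2)n1` gives 5420 nM, and compound 3 `Cc1noc(C)c1-c1cnc(N)c(Oc2ccc(C(=O)Nc3ccccc3)cc2)n1` gives 11800 nM. Both changes on the amide-type nitrogen lowered the number: an 8.0-fold lower number from compound 1 to compound 2 (0.90 log units; beyond the scatter) and a 3.7-fold lower number from compound 1 to compound 3 (0.56 log units; beyond the scatter), while a 2.2-fold higher number from compound 2 to compound 3 (0.34 log units; beyond the scatter).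

Compound 4 `Cc1noc(C)c1-c1cnc(N)c(Oc2ccc(C(=O)Nc3ccccc3Cl)cc2)n1` differs from compound 1 by 2-chlorophenyl in place of cyclopropyl on an amide-type nitrogen. The step that bears most directly on it is that from compound 1 to compound 3, since compound 3 already carries a phenyl on the same nitrogen; the step to compound 2 shows the same direction. For the measured compounds named here, the added chlorine has no counterpart among the measured compounds, so its own contribution is unknown. The author therefore expects compound 4 to land close to compound 3, with a step of a 4.8-fold lower number from compound 1 to compound 4 (0.68 log units; beyond the scatter) in this assay. The estimate for compound 4 is 9000 nM, with a range from 3000 nM to 27000 nM.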

Compound 4, half-maximal inhibitory concentration: > 100000 nM
Compound 4: a limit, no number; the forecaster's own chance of this, stated with the estimate: 5%; middle value at least 11-fold (1.04 log units) from the limit.
By their numbers in this assay, from the lowest: compound 2; then compound 3; then compound 1. At a limit, above all of these: compound 4.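

The value for compound 4 in this assay is a limit of the assay and not a number: the limit of > 100000 nM in this assay, at which 1 of the 4 values shown sits. Even so, chloro in place of hydrogen on an aromatic carbon gives an at least 8.4-fold higher number from compound 3 to compound 4 (0.92 log units; beyond the scatter), so a single substituent on the phenyl is enough to undo what phenyl had gained on this amide-type nitrogen. The earlier gains over cyclopropyl therefore do not extend to 2-chlorophenyl, with an at least 2.3-fold higher number from compound 1 to compound 4 (0.36 log units; beyond the scatter) and an at least 18-fold higher number from compound 2 to compound 4 (1.26 log units; beyond the scatter).

The compounds shown leave open whether this loss is specific to chloro or would also follow from fluoro, methyl or methoxy on the same phenyl. They also leave open how far the true value of compound 4 lies past its limit, and so the full size of these steps.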